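Three aryl ureas and a dichlorophenyl newcomer

The source may report more compounds than this note shows. Statements on the series, on what has been measured and on what is new or still open speak of the compounds shown alone.

Three ureas built on a shared core were examined in an assay on microsomes from intestine for inhibition of acyl-CoA:cholesterol acyltransferase (Oryctolagus cuniculus); on this read-out lower numbers stand for stronger inhibition and higher numbers for weaker inhibition. Compound 1 `CC(C)c1cccc(C(C)C)c1NC(=O)NCC1(c2cccc3ccccc23)CCCC1` gives 34 nM in this assay. Compound 2 `O=C(NCC1(c2ccccc2)CCCCC1)Nc1ccccc1C(F)(F)F` gives 200 nM. Compound 3 `COc1cccc(NC(=O)NCC2(c3ccccc3)CCCCC2)c1` gives 2500 nM, the highest number of the three; its gaps to compound 2 and to compound 1 both lie beyond the usual scatter, so compound 3 stands as the weakest inhibitor in this set.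

Compound 4 `O=C(NCC1(c2ccccc2)CCCCC1)Nc1ccc(Cl)c(Cl)c1` has not yet been measured in this assay. It differs from compound 3 in one place: 3,4-dichlorophenyl in place of 3-methoxyphenyl on an amide-type nitrogen. Among the measured compounds shown here, no directly comparable pair among the measured compounds shows what such a change does here. The aryl group on the urea nitrogen is the only part that varies between compound 2 and compound 3, and because compound 2 gives 200 nM while compound 3 gives 2500 nM, a different aryl substituent can move the number well beyond the scatter. For compound 4 a step of a 4.2-fold lower number from compound 3 to compound 4 (0.62 log units; beyond the scatter) toward a lower number is expected, giving an estimated 600 nM with a range from 150 nM to 2500 nM.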

Compound 4, half-maximal inhibitory concentration: 3800 nM
Compound 4: the middle estimate sits 6.3-fold (0.80 log units) below what was measured, outside the stated range (above it).
By their numbers in this assay, from the lowest: compound 1; then compound 2; then compounds 3 and 4 (each within the scatter of the next).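

In this assay, 3,4-dichlorophenyl in place of 3-methoxyphenyl on an amide-type nitrogen gives a 1.5-fold higher number from compound 3 to compound 4 (0.18 log units; within the scatter) and so leaves compound 3 and compound 4 indistinguishable on this read-out. Compound 2 at 200 nM and compound 3 at 2500 nM had shown that the aryl group at this place can matter, whereas this pair shows that exchanging one aryl group for another at the same place need not separate two compounds. No independent measurement bears on this result.

The compounds shown leave open whether an amine or a carboxylic acid on this aryl ring would separate from compound 3 on this read-out. They also leave open whether 3,4-dichlorophenyl would behave the same way on the core of compound 1.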